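The compounds below may be only part of what the source reports. "The series", "measured", "known", "first", "only" and "open" are said of these compounds alone.

The three measured compounds share one core: compound 1 `Cc1c(F)cc(C(=O)NC2CCCCCC2)c(=O)n1Cc1ccc(F)cc1`, compound 2 `Cc1ccc(C(=O)NC2CCCCCC2)c(OCc2ccc(F)cc2)n1` and compound 3 `Cc1nc(OCc2ccc(F)cc2)c(C(=O)NC2CCCCCC2)cc1Br`. In an assay on HEK293 cells for inhibition of Monoacylglycerol lipase ABHD6 (Homo sapiens), read by scintillation counting, with stated times of 30 min and 5 min (on this read-out higher numbers stand for weaker inhibition and lower numbers for stronger inhibition), compound 1 gives > 10000 nM, which is a limit of the assay rather than a number. Compound 2 likewise gives only a limit in this assay, namely > 10000 nM. Compound 3 too stops at a limit in this assay, giving > 10000 nM. Within the data shown here, because all three values sit at the limit of > 10000 nM in this assay, at which 3 of the 3 values shown sit, the one structural step among them, a step that the two limits leave unreadable from compound 2 to compound 3, cannot be read at all.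

Compound 4 `Cc1nc(OCc2ccc(F)cc2)c(C(=O)NC2CCCCCC2)cc1-c1ccc(F)cc1` differs from compound 3 by 4-fluorophenyl in place of bromo on an aromatic carbon. Among the measured compounds shown here, no measured step bears on this change: every value shown is a limit, and compound 3 offers only a floor of weak inhibition, not a number to step from. The expected step is a step that the limit leaves unreadable from compound 3 to compound 4, which amounts to no readable change from where compound 3 stands. Compound 4 is therefore estimated at 15000 nM in this assay, with a range from 2000 nM to 60000 nM, and most likely the assay will again report only a limit.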

Compound 4, half-maximal inhibitory concentration: > 10000 nM
Compound 4 ended at the assay's limit (the forecaster's own chance of this, stated with the estimate: 70%); the middle value is on the limit's open side.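

Compound 4 also stops at a limit of the assay, so the steps to it from compound 3 and from compound 2 cannot be read: the limit of > 10000 nM in this assay, at which 4 of the 4 values shown sit. The compounds shown leave open what change to the shared core, if any, would give a readable number in this assay at all.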